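This account rests on a few compounds, and the source may have more. Where it says the series, first, only, none or still open, it means among the compounds named here.

In a physicochemical assay for solubility, read by chemiluminescence (on this read-out lower numbers stand for lower solubility and higher numbers for higher solubility), three compounds share one core and differ only in the group on an amide-type nitrogen. Compound 1 `O=C(CN(C(=O)c1ccc(-c2ccccn2)cc1)C1CCCCC1)Nc1cc(F)cc(F)c1` carries cyclohexyl and reads 6 ug/mL on this measure. Compound 2 `O=C(CN(CC1CC1)C(=O)c1ccc(-c2ccccn2)cc1)Nc1cc(F)cc(F)c1` carries cyclopropylmethyl and reads 25 ug/mL on the same scale. Compound 3 `O=C(CN(C(=O)c1ccc(-c2ccccn2)cc1)C1CCCOC1)Nc1cc(F)cc(F)c1` carries oxan-3-yl and stands highest of the three with 56 ug/mL as its reading. Compound 4 `O=C(CN(C(=O)c1ccc(-c2ccccn2)cc1)C1CCOCC1)Nc1cc(F)cc(F)c1` has oxan-4-yl in place of oxan-3-yl on an amide-type nitrogen and the rest of the structure stays the same. The measured steps that bear on this are a 9.3-fold higher number from compound 1 to compound 3 (0.97 log units; beyond the scatter) and a 2.2-fold higher number from compound 2 to compound 3 (0.35 log units; beyond the scatter) as well as a 4.2-fold higher number from compound 1 to compound 2 (0.62 log units; beyond the scatter) and all three are modest. None of them exchanges oxan-3-yl for oxan-4-yl, so the data offer no direct test. Compound 4 keeps the same atoms as compound 3, so it is expected to hold on to the gain seen in a 9.3-fold higher number from compound 1 to compound 3 (0.97 log units; beyond the scatter) without adding to it. The expected change is no change at the digits printed from compound 3 to compound 4 (within the scatter) and it is estimated to stay within the scatter, with no direction favoured. In this assay the estimate for compound 4 is 56 ug/mL with an expected range of 25 ug/mL to 125 ug/mL as the likely span.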

Compound 4, solubility: 99 ug/mL
Compound 4: middle estimate off by 1.8-fold (0.25 log units), on the low side; the range from low to high includes it.
By their numbers in this assay, from the lowest: compound 1; then compound 2; then compounds 3 and 4 (each within the scatter of the next).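

In this assay, swapping oxan-3-yl for oxan-4-yl on the amide-type nitrogen gives a 1.8-fold higher number from compound 3 to compound 4 (0.25 log units; within the scatter), so this assay cannot tell these two placements of the ring oxygen apart. Among these four compounds, both oxygen-containing rings read beyond the scatter of the two all-carbon groups, and oxan-4-yl in place of cyclopropylmethyl gives a 4.0-fold higher number from compound 2 to compound 4 (0.60 log units; beyond the scatter), while oxan-4-yl in place of cyclohexyl gives a 17-fold higher number from compound 1 to compound 4 (1.22 log units; beyond the scatter), the only step here printed as large. No measurement shown here gives a reason for these numbers.

Going by these compounds, it remains open how a smaller oxygen ring such as oxetan-3-yl or an open chain such as 2-methoxyethyl would read at this nitrogen. A ring carrying an amine, such as piperidin-4-yl, or a carboxylic acid is equally untested among the compounds shown.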